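A few compounds are considered here, and "the series" means these few. Any claim that something is new, unique, unknown or untested is made for them only; others in the source may bear on it.

Measured so far:
compound 1 `Cc1ccc(S(=O)(=O)NCc2ccc(CNC(=O)c3ccc(F)cn3)cc2)cc1`: 1000 nM
compound 2 `O=C(NCc1ccc(CNS(=O)(=O)c2ccc(CN3CCCC3)cc2)cc1)c1ccc(F)cc1`: 1 nM

In an assay on MDA-MB-231 cells for binding affinity to C-X-C chemokine receptor type 4 (Homo sapiens), read by fluorescence and microscopy, with stated times of 10 min and 30 min (a lower number here means that less compound is needed, a higher number that more compound is needed for the effect), compound 2 gives 1 nM, the lowest of the two numbers shown. Its nearest neighbour is compound 1, which in this assay gives 1000 nM, a gap far beyond the scatter. Compound 3 `O=C(NCc1ccc(CNS(=O)(=O)c2ccc(F)cc2)cc1)c1ccc(F)cc1` is not yet measured; it differs from compound 2 by fluoro in place of (pyrrolidin-1-yl)methyl on an aromatic carbon. Among the measured compounds shown here, no step between measured compounds isolates this change, so the account expects a large rise in this assay from compound 2 to compound 3, estimated at a 300-fold higher number from compound 2 to compound 3 (2.48 log units; beyond the scatter). For compound 3 the estimated value in this assay is 300 nM, with a range from 30 nM to 3000 nM.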

Compound 3, effective concentration (reported as EC, without a stated level of effect): 1 nM
Beside the measured number, compound 3's estimate is 300-fold (2.48 log units) above it; the whole stated range lies above it.
By their numbers in this assay, from the lowest: compounds 2 and 3 (each within the scatter of the next); then compound 1.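

In this assay, fluoro in place of (pyrrolidin-1-yl)methyl on an aromatic carbon, para to a large group, brings no change at the digits printed from compound 2 to compound 3 (within the scatter). At this position, then, the low number of compound 2 does not depend on the (pyrrolidin-1-yl)methyl group, and fluoro serves equally well. Nothing measured here gives a cause for this result. Compound 1 differs from compound 2 and compound 3 in more than one place, so what separates it from them stays unresolved. On these data alone, whether a hydrogen, a nitrile or a carboxylic acid at this aromatic carbon would keep the number also remains open.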